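The compounds below may be only part of what the source reports. "The series", "measured", "known", "first", "only" and "open" are said of these compounds alone.

Measured in a toxicity assay on HepG2 2.2.15 cells (Homo sapiens) for cytotoxicity, read by CellTiter-Glo; on this read-out higher numbers stand for lower toxicity in this test and lower numbers for higher toxicity in this test:
- Compound 1 `N#CC1CC(=O)N(c2cnn3c2CN(C(=O)Nc2cc(F)c(F)c(F)c2)C(C2CC2)C3)C1`: > 200000 nM, a limit of the assay.
- Compound 2 `Cc1cnc(C2CC(=O)N(c3cnn4c3CN(C(=O)Nc3cc(F)c(F)c(F)c3)C(C3CC3)C4)C2)s1`: 96200 nM.

Among the measured compounds shown here, compound 2 holds the only true number so far. Compound 3 `O=C1CC(c2ccc(F)cc2)CN1c1cnn2c1CN(C(=O)Nc1cc(F)c(F)c(F)c1)C(C1CC1)C2` has 4-fluorophenyl in place of 5-methyl-1,3-thiazol-2-yl on a saturated ring carbon. For the measured compounds named here, the sole measured step at this carbon, an at least 2.0-fold lower number from compound 1 to compound 2 (0.31 log units; beyond the scatter), is at least modest, but it replaces a cyano group and starts from a limit, so it is a weak guide. No step beyond the scatter is therefore expected in this assay. The estimated step is a 1.2-fold lower number from compound 2 to compound 3 (0.08 log units; within the scatter). Compound 3 is expected at 80000 nM, with an estimated range of 30000 nM to 200000 nM.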

Compound 3, half-maximal cytotoxic concentration: 32100 nM
Estimate against measurement, compound 3: 2.5-fold (0.40 log units) above; the range from low to high includes it.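

In this assay, among the compounds shown here, a 3.0-fold lower number from compound 2 to compound 3 (0.48 log units; beyond the scatter) gives the first comparison at this saturated ring carbon with true numbers at both ends: exchanging one aromatic ring for another, 5-methyl-1,3-thiazol-2-yl for 4-fluorophenyl, does shift the read-out. The cyano end of the series is a limit of the assay, so an at least 6.2-fold lower number from compound 1 to compound 3 (0.79 log units; beyond the scatter) is only a bound: the limit of > 200000 nM in this assay, at which 1 of the 3 values shown sits.

Open, on these data alone, is how an amine or a carboxylic acid on this carbon would read in this assay. Also open, as far as these compounds go, is whether the gap between these two aromatic rings persists with other changes on the shared core.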